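A few compounds are considered here, and "the series" means these few. Any claim that something is new, unique, unknown or untested is made for them only; others in the source may bear on it.

Working notes on the series. Compound 1 `O=C(Nc1ccc(Oc2ccnc3[nH]ccc23)cc1)c1ccc(-c2ccc(Cl)cc2)cn1` is the reference member. In a functional assay on MCF7 cells (Homo sapiens) for cytotoxicity, read by MTT assay, with a stated time of 72 h (a lower number here means a stronger inhibitor, a higher number a weaker inhibitor), compound 1 gives > 10000 nM, which is a limit of the assay and not a number. Compound 2 `O=C(Nc1ccc(Oc2ccnc3[nH]ccc23)cc1)c1ccc(-c2ccc(F)cc2F)cn1` carries 2,4-difluorophenyl in place of 4-chlorophenyl on an aromatic carbon. In this assay compound 2 gives > 10000 nM, again only a limit. The step that the two limits leave unreadable from compound 1 to compound 2 stays unreadable because of the limit of > 10000 nM in this assay, at which 3 of the 3 values shown sit. Compound 3 `O=C(Nc1ccc(Oc2ccnc3[nH]ccc23)c(F)c1)c1ccc(-c2ccc(Cl)cc2)cn1` differs from compound 1 in its core by fluoro in place of hydrogen on an aromatic carbon. In this assay compound 3 gives > 10000 nM, also a limit. The step that the two limits leave unreadable from compound 1 to compound 3 is likewise not readable because of the limit of > 10000 nM in this assay, at which 3 of the 3 values shown sit.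

Compound 4 `O=C(Nc1ccc(Oc2ccnc3[nH]ccc23)c(F)c1)c1ccc(-c2ccc(F)cc2F)cn1` is not yet measured. Within the data shown here, it bears 2,4-difluorophenyl in place of 4-chlorophenyl on an aromatic carbon, the same change as the one from compound 1 to compound 2, described at a place given in the same words. The expected step that the limit leaves unreadable from compound 3 to compound 4 is set beside a step that the two limits leave unreadable from compound 1 to compound 2 and rests on compound 2 giving > 10000 nM, with no readable size from that pair. For compound 4 the estimate in this assay is 20000 nM, expected between 8000 nM and 60000 nM, most likely reported again as a limit rather than a number.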

Compound 4, half-maximal inhibitory concentration: > 10000 nM
Compound 4 was reported as a limit; the forecaster's own chance of this, stated with the estimate: 85%; the middle value does not contradict the limit.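

In this assay compound 4 gives > 10000 nM, again a limit and not a number. Neither new step, from compound 3 or compound 2 to compound 4, can be read, because every value sits at the same limit: the limit of > 10000 nM in this assay, at which 4 of the 4 values shown sit.

The compounds shown leave open whether 2,4-difluorophenyl in place of 4-chlorophenyl, or fluoro in place of hydrogen, changes anything in this assay.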